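This account rests on a few compounds, and the source may have more. Where it says the series, first, only, none or still open, it means among the compounds named here.

In a functional assay on cells (T-cell line, Homo sapiens) for inhibition (a lower number here means a stronger inhibitor, a higher number a weaker inhibitor), compound 1 `Clc1ccc(CCCN2CCC(COC(c3ccccc3)c3ccccc3)CC2)cc1Cl` gives 2200 nM, compound 2 `CCCN1CCC(COC(c2ccccc2)c2ccccc2)CC1` gives 17800 nM and compound 3 `CCCCCN1CCC(COC(c2ccccc2)c2ccccc2)CC1` gives 10800 nM. Compound 3 thus lies within the scatter of compound 2, and its distance from the other compound is clear: a 4.9-fold higher number from compound 1 to compound 3 (0.69 log units; beyond the scatter). The change to compound 4 `CCCCCCCCN1CCC(COC(c2ccccc2)c2ccccc2)CC1` is propyl in place of hydrogen on a saturated chain carbon, five bonds along the chain from an amine nitrogen in a ring, on a saturated chain carbon, five bonds along the chain from an amine nitrogen in a ring. Going by the values given here, the closest precedent is a lengthening of the same chain, a 1.6-fold lower number from compound 2 to compound 3 (0.22 log units; within the scatter). The larger change in an 8.1-fold higher number from compound 1 to compound 2 (0.91 log units; beyond the scatter) remains modest. A small drop in this assay is therefore expected, with a 1.7-fold lower number from compound 3 to compound 4 (0.22 log units; within the scatter) as the estimated step. Compound 4 is expected at 6500 nM, within an estimated range of 2500 nM to 15000 nM.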

Compound 4, half-maximal inhibitory concentration: 700 nM
Compound 4: the middle estimate sits 9.3-fold (0.97 log units) above what was measured; measured number outside the range, below it.
By their numbers in this assay, from the lowest: compound 4; then compound 1; then compounds 3 and 2 (each within the scatter of the next).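

In this assay, lengthening the chain on the amine nitrogen in a ring, which had changed little so far, now counts: propyl in place of hydrogen, five bonds along the chain, gives a large step (a 15-fold lower number from compound 3 to compound 4 (1.19 log units; beyond the scatter)), and the whole extension gives another (a 25-fold lower number from compound 2 to compound 4 (1.41 log units; beyond the scatter)). The plain chain also passes the 3,4-dichlorophenyl end (a 3.1-fold lower number from compound 1 to compound 4 (0.50 log units; beyond the scatter)), so that group is not required for a number of this size. No evidence at hand explains why the gain appears at this length. On these data alone, whether a still longer chain continues the trend or reverses it stays open, as does the effect of an amine or a carboxylic acid at the chain end.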